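This account rests on a few compounds, and the source may have more. Where it says the series, first, only, none or still open, it means among the compounds named here.

Of the compounds shown here, two have been measured. Compound 1, `O=C(N/N=C\C1=C(Cl)c2ccccc2CCC1)C1=C(Cl)c2ccccc2CCC1`, gives 1600 nM in a functional assay (MiaPaCa cells, Homo sapiens) for inhibition, read by sulforhodamine B assay, with a stated time of 48 h; a higher number here means a weaker inhibitor of growth, a lower number a stronger inhibitor of growth. Compound 2, `Cc1cc2c(cc1C)C(Cl)=C(C(=O)N/N=C\c1ccc(Cl)cc1)CCC2`, gives 440 nM in this assay. Of the two numbers, compound 2 holds the lower one, and the gap up to compound 1 lies beyond the usual scatter, so compound 2 is the stronger inhibitor of growth of the pair. Among the compounds with values here, no step between these two measured compounds differs in one place only, so nothing in the data says directly how a single halogen swap shifts the numbers.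

Compound 3, `Cc1cc2c(cc1C)C(Cl)=C(C(=O)N/N=C\c1ccc(F)cc1)CCC2`, has not yet been measured. Relative to compound 2 the change is fluoro in place of chloro on an aromatic carbon, a swap of one halogen for another of the same kind on a ring that is otherwise untouched. Within the data shown here, with no comparable step among the measured compounds, the expected shift is a 1.4-fold higher number from compound 2 to compound 3 (0.13 log units; within the scatter), which is to say none beyond the scatter, with only a slight lean toward a higher number. Compound 3 is therefore estimated at 600 nM, within a range of 250 nM to 1500 nM.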

Compound 3, concentration for 50% growth inhibition: 360 nM
For compound 3 the middle estimate is 1.7-fold (0.22 log units) above the measured one, within the range that was stated.
By their numbers in this assay, from the lowest: compounds 3 and 2 (each within the scatter of the next); then compound 1.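

Exchanging 4-chlorophenyl for 4-fluorophenyl gives a 1.2-fold lower number from compound 2 to compound 3 (0.09 log units; within the scatter) in this assay, so at this place, on an aromatic carbon para to a large group, the data do not tell fluoro and chloro apart. Within the data shown here, this is the only step among the three compounds that differs in one place, and it gives the first direct reading of a halogen swap: here, the choice between these two halogens leaves the growth inhibition number within the scatter. No independent measurement is available to explain this result.

From the compounds shown here alone, what a methoxy group, an amine, a carboxylic acid or a plain hydrogen at this place would do to the number in this assay remains open, since the two halogens alone do not show whether the place tolerates other groups. Also open, going by these compounds, are the roles of the methyl groups and the chloro on the core of compound 2, and compound 1 differs from compound 2 in more than one place, so no single part can be credited with what separates them.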